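Methoxy in place of methyl in compound 1

The source may hold more compounds than are shown below. What is called first, only, known or untested is meant among the compounds shown, and "the series" means these compounds.

In a physicochemical assay for solubility, at pH 7.4 (a higher number here means a more soluble compound, a lower number a less soluble compound), compound 1 `Cc1cc(NC(=O)Nc2ccc(C)c(Cl)c2)c2ccccc2n1` gives 300 nM and stands second of three numbers, above compound 2 `Cc1cc(NC(=O)Nc2cccc(C(N)=O)c2)c2ccccc2n1` at 100 nM on the same scale, while compound 3 `Cc1ccc(NC(=O)Nc2cc(C)nc3ccccc23)cc1` stands first with 1300 nM on that scale. Compound 4 `COc1ccc(NC(=O)Nc2cc(C)nc3ccccc23)cc1Cl` has methoxy in place of methyl on an aromatic carbon and awaits measurement. Within the data shown here, no measured step makes this change. Among the measured compounds shown here, the only step from compound 1 puts hydrogen in place of chloro on an aromatic carbon and shows a 4.3-fold higher number from compound 1 to compound 3 (0.64 log units; beyond the scatter) as a modest move, so it bears only indirectly. No step beyond the scatter is therefore expected, and the estimated step is a 1.1-fold higher number from compound 1 to compound 4 (0.04 log units; within the scatter) in either direction. Compound 4 is expected at 330 nM within an estimated range of 120 nM to 900 nM overall.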

Compound 4, solubility: 400 nM
Compound 4: the middle estimate sits 1.2-fold (0.08 log units) below what was measured; measured number inside the range.
By their numbers in this assay, from the lowest: compound 2; then compounds 1 and 4 (each within the scatter of the next); then compound 3.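

In this assay, methoxy in place of methyl on an aromatic carbon, ortho to a chloro group, gives a 1.3-fold higher number from compound 1 to compound 4 (0.12 log units; within the scatter) and so stays within the scatter. Among these compounds, the earlier step at the chloro group itself, a 4.3-fold higher number from compound 1 to compound 3 (0.64 log units; beyond the scatter), lay beyond the scatter, so this is the first reading at the methyl position, and it shows no clear shift with the added hydrogen-bond acceptor. Nothing measured here offers an explanation for this result.

Going by these compounds, whether methoxy would behave the same way without the chloro group remains open. So does what an amine or a longer ether chain would give on this carbon.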